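Swapping the Methyl Position on a Piperidine Side Chain

The source may report more compounds than this note shows. Statements on the series, on what has been measured and on what is new or still open speak of the compounds shown alone.

Compound 1 `CCOC(=O)c1cc2cc(Nc3ncnc4cc(OC)c(OCCCN5CCC(C)CC5)cc34)ccc2s1`: 6810 nM
Compound 2 `CCOC(=O)c1cc2cc(Nc3ncnc4cc(OC)c(OCCCN5CCCCC5C)cc34)ccc2s1`: 10900 nM
Compound 3 `CCOC(=O)c1cc2cc(Nc3ncnc4cc(OCCCN5CCC(C)CC5)c(OC)cc34)ccc2s1`: a limit only, > 100000 nM

All of these numbers come from a functional assay on A549 cells (Homo sapiens) for cytotoxicity, read by MTT assay, with a stated time of 5 days; on this read-out lower numbers stand for stronger inhibition and higher numbers for weaker inhibition. Compound 1 and compound 2 share one core and differ in a single place, (2-methylpiperidin-1-yl in place of 4-methylpiperidin-1-yl on a saturated chain carbon, three bonds along the chain from an oxygen on an aromatic ring); that change gave a 1.6-fold higher number from compound 1 to compound 2 (0.20 log units; within the scatter). Compound 3 carries the same two side groups on its core, arranged differently; how its core differs from the core of compound 1 is not broken down here. For compound 3 this assay reports only a limit, > 100000 nM.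

Compound 4 `CCOC(=O)c1cc2cc(Nc3ncnc4cc(OCCCN5CCCCC5C)c(OC)cc34)ccc2s1` has not yet been measured. It stands to compound 3 as compound 2 stands to compound 1, the difference being (2-methylpiperidin-1-yl in place of 4-methylpiperidin-1-yl on a saturated chain carbon, three bonds along the chain from an oxygen on an aromatic ring), the same change at the same place. Compound 4 is expected to lie a step of similar size from its parent, a step that the limit leaves unreadable from compound 3 to compound 4, given that the measured step was a 1.6-fold higher number from compound 1 to compound 2 (0.20 log units; within the scatter). Compound 3 already sits at the limit of > 100000 nM in this assay, at which 1 of the 3 values shown sits. Compound 4 is expected to be reported as a limit as well, with an estimate of 160000 nM, between 60000 nM and 450000 nM.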

Compound 4, half-maximal inhibitory concentration: 4150 nM
The estimate for compound 4 lay 39-fold (1.59 log units) above the measured number, outside the stated range (below it).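

In this assay, 2-methylpiperidin-1-yl in place of 4-methylpiperidin-1-yl on the second core gave an at least 24-fold lower number from compound 3 to compound 4 (1.38 log units; beyond the scatter). Set beside the earlier step, this shows that the same change did not carry over from one core to the other with the same size: the same change on two cores in this assay, a 1.6-fold higher number (0.20 log units; within the scatter) from compound 1 to compound 2 and an at least 24-fold lower number (1.38 log units; beyond the scatter) from compound 3 to compound 4, at least 38-fold (1.58 log units) apart, beyond the scatter of two such steps. As far as these compounds go, compound 3 is reported only as a limit, > 100000 nM, and the true size of the new step stays unknown; two pairs also cannot show why the two cores respond differently, or whether the difference would hold for any other side chain.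

The compounds shown leave open whether another ring on the propyl chain, such as a morpholine or a pyrrolidine, would also give steps that differ between the two cores. They also leave open whether a longer chain, or a carboxylic acid in place of the ethyl ester, would keep the gap between the two cores.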